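The compounds below may be only part of what the source reports. "The series", "measured", "known", "first", "only" and "open" are said of these compounds alone.

Compound 1, `CC/N=C(/NC#N)NCCCCn1nc(-c2ccccc2)ccc1=O`: 92 mg/kg
Compound 2, `N#CNC(=N)NCCCCn1nc(-c2ccccc2)ccc1=O`: 77.2 mg/kg
Compound 3, `C/N=C(\S)NCCCCCn1nc(-c2ccccc2)ccc1=O`: 35.3 mg/kg

In a functional assay on the whole organism (stomach) with Rattus norvegicus as the target (a higher number here means that more compound is needed for the effect, a lower number that less compound is needed), compound 3 gives the lowest of the three numbers. Its nearest neighbour is compound 2, and that gap is a 2.2-fold lower number from compound 2 to compound 3 (0.34 log units; beyond the scatter). The gap to compound 1 is wider, a 2.6-fold lower number from compound 1 to compound 3 (0.42 log units; beyond the scatter). Compound 4, `C/N=C(/NC#N)N(C)CCCCn1nc(-c2ccccc2)ccc1=O`, has not yet been measured in this assay. Compared with compound 3 its change is a group of 8 heavy atoms (4 carbon, 4 nitrogen; no ring) in place of a group of 6 heavy atoms (3 carbon, 2 nitrogen, 1 sulfur; no ring), on a saturated chain carbon, four bonds along the chain from an aromatic nitrogen.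

Among the measured compounds shown here, one measured step bears directly on this change, in the opposite direction: the step of a 2.6-fold lower number from compound 1 to compound 3 (0.42 log units; beyond the scatter) removed a group of the same kind that now enters and put in the sulfur-bearing group that now leaves. The step of a 1.2-fold lower number from compound 1 to compound 2 (0.08 log units; within the scatter) also touched the entering kind of group, at the amine nitrogen, and stayed within the scatter. For the measured compounds named here, compound 4 differs from compound 1 in the methyl groups on its nitrogens, a change for which no measured pair exists. The expectation is therefore a modest rise in the number, roughly undoing the step from compound 1, estimated as a 2.3-fold higher number from compound 3 to compound 4 (0.36 log units; beyond the scatter). Compound 4 is expected to give about 80 mg/kg, with a range from 40 mg/kg to 160 mg/kg.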

Compound 4, dose for half-maximal effect: > 100 mg/kg
Compound 4 was reported as a limit; the forecaster's own chance of this, stated with the estimate: 5%; at least 1.2-fold (0.09 log units) between middle value and limit.
By their numbers in this assay, from the lowest: compound 3; then compounds 2 and 1 (each within the scatter of the next). At a limit, above all of these: compound 4.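

In this assay compound 4 gives > 100 mg/kg, which is a limit and not a number. Even so, the step of an at least 2.8-fold higher number from compound 3 to compound 4 (0.45 log units; beyond the scatter) is the first measured case of this nitrogen-rich, nitrile-bearing group entering in place of the sulfur-bearing group on a saturated chain carbon, four bonds along the chain from an aromatic nitrogen, and its floor alone clears the scatter, so the lower number of compound 3 is lost with this exchange. The other two steps, an at least 1.2-fold higher number from compound 2 to compound 4 (0.11 log units; that floor lies within the scatter) and an at least 1.0-fold higher number from compound 1 to compound 4 (0.03 log units; that floor lies within the scatter), cannot be read as changes, so the result does not show that the methyl groups on the nitrogens of compound 4 shift the number relative to the other nitrile-bearing compounds.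

As far as these compounds go, how far compound 4 really lies past compounds 1 and 2 stays open: the limit of > 100 mg/kg in this assay, at which 1 of the 4 values shown sits. The compounds shown also leave open how a simple amine or a carboxylic acid would fare at this place, and whether a longer chain would alter the gap between the sulfur-bearing and nitrile-bearing groups.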